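Ester chain extension and plasma half-life in the biaryl amide series

The compounds below may be only part of what the source reports. "The series", "measured", "known", "first", "only" and "open" are said of these compounds alone.

Measured compounds:
compound 1 `COC(=O)c1cccc(-c2cc(C(=O)Nc3ccncc3)ccc2CN)c1` — 1.52 h
compound 2 `COC(=O)c1cccc(-c2cc(C(=O)Nc3ccncc3F)ccc2CN)c1` — 1.08 h
compound 3 `CCCCOC(=O)c1cccc(-c2cc(C(=O)Nc3ccncc3)ccc2CN)c1` — 0.367 h

In an ADME assay on a cell-free system (plasma, Homo sapiens) for metabolic stability, read by LC-MS (a higher number here means that the compound lasts longer, a lower number that the compound disappears faster), compound 2 gives 1.08 h, the second highest of the three numbers. Compound 1 is nearest to it and the two lie within the scatter of each other, as the step of a 1.4-fold lower number from compound 1 to compound 2 (0.15 log units; within the scatter) shows. Compound 3 sits furthest away, with the lower number.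

The next compound, compound 4 `NCc1ccc(C(=O)Nc2ccncc2F)cc1-c1cccc(C(=O)OCCO)c1`, is not yet measured. Relative to compound 2 the change is hydroxymethyl in place of hydrogen on a saturated chain carbon bound to an oxygen next to a carbonyl group.

Of the measured steps, only one touches the same place: a 4.1-fold lower number from compound 1 to compound 3 (0.62 log units; beyond the scatter), where the chain at the ester oxygen was lengthened. That step was modest but beyond the scatter and pointed downward. The step of a 1.4-fold lower number from compound 1 to compound 2 (0.15 log units; within the scatter) concerns the aromatic fluoro and is already built into compound 2, so it does not add to the expectation. Taking the downward step on chain extension as the guide, and noting that hydroxymethyl is a shorter addition than propyl, a lower number in this assay is expected for compound 4, of the size a 2.0-fold lower number from compound 2 to compound 4 (0.29 log units; within the scatter), smaller than that seen for propyl.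

The estimate for compound 4 in this assay is therefore 0.55 h, with a range of 0.25 h to 1.2 h.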

Compound 4, half-life: 1.35 h
The estimate for compound 4 lay 2.5-fold (0.39 log units) below the measured number, outside the stated range (above it).
By their numbers in this assay, from the lowest: compound 3; then compounds 2, 4 and 1 (each within the scatter of the next).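

At the saturated chain carbon bound to an oxygen next to a carbonyl group, this assay gives a 1.3-fold higher number from compound 2 to compound 4 (0.10 log units; within the scatter), so replacing methoxycarbonyl with (2-hydroxyethoxy)carbonyl produces no readable change on the fluoro-bearing parent. Extension at this place therefore does not always go with a readable loss, since the propyl change gave a 4.1-fold lower number from compound 1 to compound 3 (0.62 log units; beyond the scatter) on the parent without fluoro, and the two chain changes now part in outcome, although they were made on different parents. Nothing shown bears on why the hydroxymethyl and propyl changes part in this way.

The compounds shown leave open whether the difference follows the terminal hydroxy group or the shorter chain, a question that an ethyl ester and a 2-methoxyethyl ester would help to separate, ideally on both the fluoro-bearing parent and the parent without fluoro. Also open, from the compounds shown here alone, is how this assay would read for a carboxylic acid in place of the ester, or for a 2-aminoethyl ester, at this same place.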